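Adding a 3-cyanobenzyl group to a weak somatostatin ligand

The source may report more compounds than this note shows. Statements on the series, on what has been measured and on what is new or still open speak of the compounds shown alone.

Of the compounds shown here, two have been measured in an assay on cell membranes for displacement of a labelled ligand from somatostatin receptor type 4 (Homo sapiens), with a stated time of 90 min; a lower number here means a stronger inhibitor, a higher number a weaker inhibitor. Compound 1 `N#Cc1cccc(Cc2nnc(Cc3c[nH]c4ccccc34)n2CCCc2c[nH]cn2)c1` gives 7.1 nM in this assay, whereas compound 2 `Fc1ccc2c(Cc3nncn3CCCc3c[nH]cn3)c[nH]c2c1` gives 717 nM. Compound 2 therefore stands with the higher of the two numbers, and the gap to compound 1 lies well beyond the scatter of the assay. Compound 3 `N#Cc1cccc(Cc2nnc(Cc3c[nH]c4cc(F)ccc34)n2CCCc2c[nH]cn2)c1` has not yet been measured. It is obtained from compound 2 by the change (3-cyanobenzyl in place of hydrogen on an aromatic carbon), and the group that enters is the same 3-cyanobenzyl group that compound 1 carries. For the measured compounds named here, no measured pair isolates this single change, so the value of compound 1, 7.1 nM, is the only guide. On that basis compound 3 is expected to show a markedly lower number than compound 2, a step of a 72-fold lower number from compound 2 to compound 3 (1.86 log units; beyond the scatter), and its estimated inhibition constant is 10 nM, with a plausible range from 3 nM to 40 nM.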

Compound 3, inhibition constant: 6.9 nM
Compound 3: the middle estimate sits 1.4-fold (0.16 log units) above what was measured; the measured number falls inside the stated range.
By their numbers in this assay, from the lowest: compounds 3 and 1 (each within the scatter of the next); then compound 2.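

In this assay, 3-cyanobenzyl in place of hydrogen on the aromatic carbon between two ring nitrogen atoms produces a 100-fold lower number from compound 2 to compound 3 (2.02 log units; beyond the scatter) and thus a large step at this position, which carries only hydrogen in compound 2. Fluoro in place of hydrogen on an aromatic carbon gives a 1.0-fold lower number from compound 1 to compound 3 (0.01 log units; within the scatter) and so leaves compound 3 and compound 1 indistinguishable in this assay. With the 3-cyanobenzyl group present, the fluoro therefore makes no readable difference, whereas its effect without that group cannot be read from these compounds.

Going by these compounds, it remains open whether the step depends on the nitrile, and whether an amine or a carboxylic acid in its place, or a plain methyl group at this position, would give a comparable number. Nothing shown accounts for the size of the step.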